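Dog liver microsome half-life: from compound 2 to compound 3

The compounds below may be only part of what the source reports. "The series", "measured", "known", "first", "only" and "open" are said of these compounds alone.

Compound 1 `C=CC(=O)NCc1coc(-c2c(N)ncnc2Nc2ccc(OCc3ccccn3)c(F)c2)n1`: 0.733 h
Compound 2 `C=CC(=O)NCc1coc(-c2c(N)ncnc2Nc2ccc(Oc3cc(Cl)ccc3Cl)c(Cl)c2)n1`: > 1.66 h (a limit)

Both compounds were tested in an in vitro ADME assay on microsomes from liver (Canis lupus familiaris) for metabolic stability, tested at 5 uM; a higher number here means that the compound lasts longer, a lower number that the compound disappears faster. Compound 2 gives > 1.66 h, which is a limit of the assay and not a number. This is the limit of > 1.66 h in this assay, at which 1 of the 2 values shown sits. Going by these compounds, its true position in this assay therefore remains open.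

Compound 3 `C=CC(=O)NCc1coc(-c2c(N)ncnc2Nc2ccc(Oc3cccnc3)c(Cl)c2)n1` differs from compound 2 in one place: pyridin-3-yl in place of 2,5-dichlorophenyl on an oxygen on an aromatic ring. Pyridin-3-yl stands in place of 2,5-dichlorophenyl on an oxygen on an aromatic ring. Among the compounds with values here, no step between measured compounds shows what such a change does in this assay, so any expectation here is loosely held. A shorter half-life than that of compound 2 is expected, though the change may not exceed the usual scatter. Within the data shown here, the only exact reading comes from compound 1 at 0.733 h, and the expectation is drawn partway towards it. The estimated change is an at least 1.3-fold lower number from compound 2 to compound 3 (0.14 log units; that floor lies within the scatter). For compound 3 the expected half-life is 1.2 h, with an estimated range of 0.5 h to 2.6 h.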

Compound 3, half-life: 0.65 h
The estimate for compound 3 lay 1.8-fold (0.27 log units) above the measured number; the range from low to high includes it.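

In this assay, the change of 2,5-dichlorophenyl to pyridin-3-yl on an oxygen on an aromatic ring now has its first reading, and it gives an at least 2.5-fold lower number from compound 2 to compound 3 (0.40 log units; beyond the scatter). The step lies beyond the usual scatter, which shows that the group on this oxygen can move the half-life, and that the move runs downward for this change. Compound 2 stands at a limit of the assay and not at a number, so the printed size is a floor and the full size of the step stays unknown: the limit of > 1.66 h in this assay, at which 1 of the 3 values shown sits.

The change swaps two things at once, removing both chlorine atoms and bringing in a ring nitrogen, and this single step cannot tell which of them carries the drop in half-life. A plain phenyl or a 3-chlorophenyl on the same oxygen would separate the two, and a compound whose half-life reads as an exact number in place of the limit would fix how large the step really is.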